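The source may hold more compounds than are shown below. What is called first, only, known or untested is meant among the compounds shown, and "the series" means these compounds.

Measured so far in a functional assay on MV4-11 cells (Homo sapiens) for antiproliferative activity, read by luminescence and CellTiter-Glo, with a stated time of 72 h (a lower number here means a stronger inhibitor, a higher number a weaker inhibitor), with these values
Compound 1 `COc1cc2cnn(Cc3ccc(F)cc3)c2cc1-c1c(C)noc1C` gives 1900 nM
Compound 2 `CNc1cc(-c2ccc3cnn(Cc4ccc(F)cc4)c3c2)cn(C)c1=O` gives 2390 nM

Compound 2 (2390 nM) lies within the scatter of compound 1 (1900 nM), so the two values set no order between them. Compound 3 `CNc1cc(-c2ccc3cnn(Cc4ccc(F)c(F)c4)c3c2)cn(C)c1=O` carries a single change from compound 2, namely fluoro in place of hydrogen on an aromatic carbon, ortho to a fluoro group and meta to a large group, so that 4-fluorobenzyl becomes 3,4-difluorobenzyl.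

Among the compounds with values here, no measured pair differs in one place only, so no measured step is available as a guide to this change. In this assay no shift beyond the scatter is expected, in either direction. The estimated move is a 1.2-fold lower number from compound 2 to compound 3 (0.08 log units; within the scatter) and it is expected to stay within the scatter. Compound 3 is expected at 2000 nM with an estimated range from 900 nM to 4500 nM for this measurement.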

Compound 3, half-maximal inhibitory concentration: 320 nM
Compound 3: middle estimate off by 6.3-fold (0.80 log units), on the high side; measured number below the stated range.
By their numbers in this assay, from the lowest: compound 3; then compounds 1 and 2 (each within the scatter of the next).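

In this assay the benzyl ring proves to be a sensitive part of the series: fluoro in place of hydrogen on the aromatic carbon ortho to a fluoro group, which turns 4-fluorobenzyl into 3,4-difluorobenzyl, gives a 7.5-fold lower number from compound 2 to compound 3 (0.87 log units; beyond the scatter) and lies beyond the scatter. Within the data shown here, this is the first change in one place that can be read here, as compound 1 and compound 2 differ in more than one place and their values set no order, so a single added fluorine is now known to be enough to move the number at this position. No measured evidence at hand bears on the reason for this step.

Going by these compounds, it remains open whether the step is specific to fluoro or would also appear with another group at this place, such as chloro, methyl or methoxy, or with an amine or a carboxylic acid. On these data alone, it is also open whether 3,4-difluorobenzyl would give a step of similar size on the core of compound 1, which carries a different group on the shared ring system.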